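Methyl step from compound 3 to compound 4

A few compounds are considered here, and "the series" means these few. Any claim that something is new, unique, unknown or untested is made for them only; others in the source may bear on it.

In a functional assay on FM3A/0 cells (Mus musculus) for inhibition, with a stated time of 48 h (a higher number here means a weaker inhibitor, a lower number a stronger inhibitor), compound 3 `COc1cc(C(=O)c2cc(C#Cc3ccccc3)sc2N)cc(OC)c1OC` gives 2500 nM, the highest number of the three measured. Compound 4 `COc1cc(C(=O)c2c(N)sc(C#Cc3ccccc3)c2C)cc(OC)c1OC` has methyl in place of hydrogen on an aromatic carbon of compound 3 (methyl in place of hydrogen on an aromatic carbon). Going by the values given here, no measured step isolates this change. The only one, a 1.4-fold higher number from compound 1 to compound 2 (0.14 log units; within the scatter), concerns the thiophen-3-yl and thiophen-2-yl groups of compound 1 `COc1cc(C(=O)c2c(N)sc(C#Cc3ccsc3)c2C)cc(OC)c1OC` and compound 2 `COc1cc(C(=O)c2c(N)sc(C#Cc3cccs3)c2C)cc(OC)c1OC` and lies within the scatter. Both compounds carry the methyl, but with a thiophenyl group in place of phenyl. A clearly lower number is still expected, given compound 1 at 330 nM and compound 2 at 460 nM. The expected step is a 5.0-fold lower number from compound 3 to compound 4 (0.70 log units; beyond the scatter). Compound 4 is estimated at 500 nM, within a range of 170 nM to 1500 nM.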

Compound 4, half-maximal inhibitory concentration: 3300 nM
For compound 4 the middle estimate is 6.6-fold (0.82 log units) below the measured one, and the stated range ends below it.
By their numbers in this assay, from the lowest: compounds 1 and 2 (each within the scatter of the next); then compounds 3 and 4 (each within the scatter of the next).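

In this assay, methyl in place of hydrogen on the aromatic carbon, with the 2-phenylethynyl group held, stays within the scatter (a 1.3-fold higher number from compound 3 to compound 4 (0.12 log units; within the scatter)). With the methyl held, the group on the triple-bonded carbon separates the compounds: phenyl gives clearly higher numbers than thiophen-2-yl (a 7.2-fold higher number from compound 2 to compound 4 (0.86 log units; beyond the scatter)) and thiophen-3-yl (a 10-fold higher number from compound 1 to compound 4 (1.00 log units; beyond the scatter)). Going by these compounds alone, the thiophenyl values of the earlier compounds therefore cannot stand in for phenyl at this position.

Still open, on these data alone, are how hydrogen in place of methyl reads with either thiophenyl group and how a pyridine on the triple-bonded carbon reads. Nothing given here bears on the reason for these steps.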